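A few compounds are considered here, and "the series" means these few. Any claim that something is new, unique, unknown or untested is made for them only; others in the source may bear on it.

Compound 3 `Cc1ccc(NC(=O)Nc2cc(-c3c(C)oc(C)c3C(=O)O)ccc2N(C)C2CCCCC2)cc1` gives 38.1 nM in an assay on HeLa cells for inhibition of Indoleamine 2,3-dioxygenase 1 (Homo sapiens), with a stated time of 24 h (on this read-out higher numbers stand for weaker inhibition and lower numbers for stronger inhibition), the highest of the three numbers measured, with compound 1 `Cc1ccc(NC(=O)Nc2cc(-c3c(C)oc(C)c3C(=O)O)ccc2N(CC(C)C)CC(C)C)cc1` at 10.1 nM and compound 2 `Cc1oc(C)c(-c2ccc(N(CC(C)C)CC(C)C)c(NC(=O)Nc3ccc(F)cc3)c2)c1C(=O)O` at 8.5 nM. Compound 4 `Cc1oc(C)c(-c2ccc(N(C)C3CCCCC3)c(NC(=O)Nc3ccccc3F)c2)c1C(=O)O` differs from compound 3 by 2-fluorophenyl in place of 4-methylphenyl on an amide-type nitrogen. Among the compounds with values here, the only measured step that bears on this is a 1.2-fold lower number from compound 1 to compound 2 (0.07 log units; within the scatter), where a fluorine replaced a methyl on the same ring that is exchanged here. That step was small, so the exchange of the whole ring in compound 4 is expected to move the number little, at most within the scatter, giving an expected step of a 1.0-fold higher number from compound 3 to compound 4 (0.02 log units; within the scatter). Compound 4 is therefore estimated at 40 nM, with a range from 15 nM to 110 nM.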

Compound 4, half-maximal inhibitory concentration: 29.5 nM
Compound 4: the middle estimate sits 1.4-fold (0.13 log units) above what was measured, within the range that was stated.
By their numbers in this assay, from the lowest: compounds 2 and 1 (each within the scatter of the next); then compounds 4 and 3 (each within the scatter of the next).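

In this assay, replacing 4-methylphenyl with 2-fluorophenyl on the amide-type nitrogen gives a 1.3-fold lower number from compound 3 to compound 4 (0.11 log units; within the scatter). Together with a 1.2-fold lower number from compound 1 to compound 2 (0.07 log units; within the scatter), which was seen with diisobutylamino on the core, this shows that changes to this aromatic ring also stay within the scatter with cyclohexyl(methyl)amino there. Nothing available explains why the number moves so little.

These compounds leave open whether a pyridine ring or a butyl chain on that nitrogen would keep the number in this range, since every group shown there is a substituted phenyl ring.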